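Phenyl in place of propyl on a carbonyl carbon

The compounds below may be only part of what the source reports. "The series", "measured", "known", "first", "only" and "open" are said of these compounds alone.

Compound 1 `CC(C)c1cc2c3c(c1OC(=O)CCl)OC(=O)[C@@]31CCCC(C)(C)[C@@H]1CC2` at 130000 nM
Compound 2 `CCC(=O)Oc1c(C(C)C)cc2c3c1OC(=O)[C@@]31CCCC(C)(C)[C@@H]1CC2` at 125000 nM
Compound 3 `CCCC(=O)Oc1c(C(C)C)cc2c3c1OC(=O)[C@@]31CCCC(C)(C)[C@@H]1CC2` at 44400 nM

In an ADME assay on MRC5 cells (Homo sapiens) for cytotoxicity, read by neutral red uptake, with a stated time of 24 h (a higher number here means a weaker inhibitor, a lower number a stronger inhibitor), compound 3 stands lowest of the three. The data show a 2.8-fold lower number from compound 2 to compound 3 (0.45 log units; beyond the scatter) and also a 2.9-fold lower number from compound 1 to compound 3 (0.47 log units; beyond the scatter) while a 1.0-fold lower number from compound 1 to compound 2 (0.02 log units; within the scatter) is the remaining step. Within the data shown here, compound 4 `CC(C)c1cc2c3c(c1OC(=O)c1ccccc1)OC(=O)[C@@]31CCCC(C)(C)[C@@H]1CC2` has phenyl in place of propyl on a carbonyl carbon, counted as phenyl in place of propyl on a carbonyl carbon and no measured step brings in a ring. These chain steps therefore guide only the expected size. With compound 3 lowest at 44400 nM a small move toward a higher number is expected. The expected step is a 1.4-fold higher number from compound 3 to compound 4 (0.13 log units; within the scatter) and it remains uncertain. For compound 4 the estimated value is 60000 nM with an expected range from 20000 nM to 170000 nM overall.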

Compound 4, half-maximal inhibitory concentration: 512000 nM
Compound 4: the middle estimate sits 8.5-fold (0.93 log units) below what was measured; measured number outside the range, above it.
By their numbers in this assay, from the lowest: compound 3; then compounds 2 and 1 (each within the scatter of the next); then compound 4.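

In this assay a ring on this carbonyl carbon gives a 12-fold higher number from compound 3 to compound 4 (1.06 log units; beyond the scatter) and also a 4.1-fold higher number from compound 2 to compound 4 (0.61 log units; beyond the scatter) as well as a 3.9-fold higher number from compound 1 to compound 4 (0.60 log units; beyond the scatter) so compound 4 stands highest of the four. The position therefore tolerates no simple extrapolation from the chains: going from ethyl to propyl lowered the number, whereas phenyl raises it well past all three chain esters. Nothing available accounts for this rise. Going by these compounds, whether a longer chain such as butyl would lower the number further remains open, as does whether a saturated ring such as cyclohexyl would raise it as phenyl does.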